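The compounds below may be only part of what the source reports. "The series", "measured", "known", "first", "only" and "open" are said of these compounds alone.

Within the data shown here, compound 3, `COc1cc(Cl)cc(-c2nn(-c3cccc(NC(=O)Nc4ccc(Cl)c(Cl)c4)c3)cc2-c2ccncc2)c1`, gives 71% in a functional assay on SNB-75 cells (Homo sapiens) for inhibition, read by sulforhodamine B assay, with a stated time of 48 h, tested at 1 uM (on this read-out lower numbers stand for a stronger effect and higher numbers for a weaker effect at the one concentration tested), the highest of the three numbers measured so far. Among the measured compounds shown here, compound 1, `COc1cc(Cl)cc(-c2nn(-c3cccc(NC(=O)Nc4ccc(Cl)c(C(F)(F)F)c4)c3)cc2-c2ccncc2)c1`, gives 68% there, and the single step of a number 3 percentage points higher from compound 1 to compound 3 (within the scatter) is within the scatter, so compound 1 and compound 3 are not separable. Compound 2, `COc1cc(Cl)cc(-c2nn(-c3cccc(NC(=O)Nc4cc(C(F)(F)F)cc(C(F)(F)F)c4)c3)cc2-c2ccncc2)c1`, gives 48%, a number well below compound 3 and beyond the scatter. Compound 4, `COc1cc(Cl)cc(-c2nn(-c3cccc(NC(=O)Nc4cccc(C(F)(F)F)c4)c3)cc2-c2ccncc2)c1`, has not yet been measured; it differs from compound 3 by 3-(trifluoromethyl)phenyl in place of 3,4-dichlorophenyl on an amide-type nitrogen. For the measured compounds named here, no measured step matches this change; the only step at hand, a number 3 percentage points higher from compound 1 to compound 3 (within the scatter), was within the scatter, and compound 2 shows that a second trifluoromethyl can lower the number. Compound 4 is therefore expected to sit near compound 3, an estimated step of a number 3 percentage points lower from compound 3 to compound 4 (within the scatter), at about 68%, within the range 52% to 84%.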

Compound 4, a percentage reported as activity, at one concentration (the size of the read-out at that concentration, not a potency): 68%
The estimate for compound 4 equals the measured number at the digits printed, and the stated range covers the measured number.
By their numbers in this assay, from the lowest: compound 2; then compounds 1, 4 and 3 (each within the scatter of the next).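

Among these compounds, on the aryl group at the amide-type nitrogen, hydrogen in place of the second trifluoromethyl gives the only step here that clears the scatter in this assay, a number 20 percentage points higher from compound 2 to compound 4 (beyond the scatter). Hydrogen in place of chloro gives no change at the digits printed from compound 1 to compound 4 (within the scatter), and 3-(trifluoromethyl)phenyl in place of 3,4-dichlorophenyl gives a number 3 percentage points lower from compound 3 to compound 4 (within the scatter), so a single trifluoromethyl serves as well as the two other substitution patterns, and only the bis(trifluoromethyl) compound stands apart. No measurement on hand explains this difference. Still open, on these data alone, is how an amine or a carboxylic acid on this aryl group would read, and whether the gap persists at other concentrations.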